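The source may hold more compounds than are shown below. What is called first, only, known or untested is meant among the compounds shown, and "the series" means these compounds.

Measured compounds:
Compound 1, `Nc1ccc(S(=O)(=O)N2CCN(c3ncc(C(O)(C(F)(F)F)C(F)(F)F)cc3C#CCO)CC2)cn1`. In an ADME assay (liver) for metabolic stability, with Liver microsome (Homo sapiens) as the target, using microsomes and NADPH, with a stated time of 30 min, tested at 1 uM (a lower number here means slower removal, a higher number faster removal of the compound), compound 1 gives < 14 mL.min-1.g-1, which is a limit of the assay and not a number.
Compound 2, `COCC#Cc1cc(C(O)(C(F)(F)F)C(F)(F)F)cnc1N1CCN(S(=O)(=O)c2ccc(N)nc2)CC1`. In this assay compound 2 gives 15 mL.min-1.g-1.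
Compound 3, `CC(C)n1cc(-c2cc(C(O)(C(F)(F)F)C(F)(F)F)cnc2N2CCN(S(=O)(=O)c3ccc(N)nc3)CC2)cn1`. In this assay compound 3 gives 38 mL.min-1.g-1.

Compound 2 stands lowest of the two numbers in the series; the nearest is compound 3, at a 2.5-fold higher number from compound 2 to compound 3 (0.40 log units; beyond the scatter). Compound 1 contributes only a limit, (the limit of < 14 mL.min-1.g-1 in this assay, at which 1 of the 3 values shown sits), so its placing against compound 2 is not settled, and the step from compound 1 to compound 2 is an at least 1.0-fold higher number from compound 1 to compound 2 (0.02 log units; that floor lies within the scatter).

Compound 4, `CC(C)(C)n1cc(-c2cc(C(O)(C(F)(F)F)C(F)(F)F)cnc2N2CCN(S(=O)(=O)c3ccc(N)nc3)CC2)cn1`, has not been measured in this assay. Relative to compound 2 the change is 1-(tert-butyl)-1H-pyrazol-4-yl in place of 3-methoxyprop-1-yn-1-yl on an aromatic carbon.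

Among the measured compounds shown here, two measured steps bear on it. The closest is a 2.5-fold higher number from compound 2 to compound 3 (0.40 log units; beyond the scatter), where a 1-isopropyl-1H-pyrazol-4-yl replaced the same 3-methoxyprop-1-yn-1-yl. The other is an at least 2.7-fold higher number from compound 1 to compound 3 (0.43 log units; beyond the scatter), pointing the same way. Compound 4 carries a 1-(tert-butyl)-1H-pyrazol-4-yl in that position, so a step of similar size and direction is expected: a modest rise in this assay from compound 2, estimated at a 3.0-fold higher number from compound 2 to compound 4 (0.48 log units; beyond the scatter).

For compound 4 the expected intrinsic clearance in this assay is therefore 45 mL.min-1.g-1, with a range of 22 mL.min-1.g-1 to 90 mL.min-1.g-1.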

Compound 4, intrinsic clearance in microsomes: 86 mL.min-1.g-1
For compound 4 the middle estimate is 1.9-fold (0.28 log units) below the measured one; the measured number falls inside the stated range.
By their numbers in this assay, from the lowest: compound 2; then compound 3; then compound 4. At a limit, below all of these: compound 1.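

In this assay, the pyrazole substituent itself matters: one added methyl, turning 1-isopropyl-1H-pyrazol-4-yl into 1-(tert-butyl)-1H-pyrazol-4-yl, gives a 2.3-fold higher number from compound 3 to compound 4 (0.35 log units; beyond the scatter) on its own. On this aromatic carbon, two atoms from the ring nitrogen, replacing 3-methoxyprop-1-yn-1-yl with the tert-butyl pyrazole gives a 5.7-fold higher number from compound 2 to compound 4 (0.76 log units; beyond the scatter), so the earlier rise with the isopropyl pyrazole was not the full extent of what this position allows, and the two pyrazoles do not behave as one group. Compound 1 stands at a limit of the assay and not a number, so an at least 6.1-fold higher number from compound 1 to compound 4 (0.78 log units; beyond the scatter) is a floor only, and the true gap from the 3-hydroxyprop-1-yn-1-yl compound stays unfixed.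

From the compounds shown here alone, whether a 1-methyl or 1-(2-hydroxyethyl) group on the same pyrazole would bring the number back towards that of compound 2 stays open, as does whether a morpholine or a short amine chain at this position would behave like the propynyl ethers or like the pyrazoles. Nothing shown gives a reason for the rise from the propynyl groups to the pyrazoles, or for the further rise with the added methyl.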